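The source may report more compounds than this note shows. Statements on the series, on what has been measured and on what is new or still open speak of the compounds shown alone.

Measured so far:
compound 1, `COc1ccc(CNCCCNS(=O)(=O)c2cc(C(F)(F)F)cc(C(F)(F)F)c2)cc1OC`: 15000 nM
compound 2, `O=S(=O)(NCCCNCc1ccc(C(F)(F)F)cc1)c1cc(C(F)(F)F)cc(C(F)(F)F)c1`: 2000 nM
compound 3, `O=S(=O)(NCCCNCc1ccccc1Cl)c1cc(C(F)(F)F)cc(C(F)(F)F)c1`: 13000 nM

All three share one core and differ only in the aryl group on the saturated chain carbon bound to an amine nitrogen. In a functional assay on Capan-2 cells (Homo sapiens) for inhibition, read by MTT assay, with a stated time of 72 h (on this read-out higher numbers stand for weaker inhibition of growth and lower numbers for stronger inhibition of growth), compound 3 gives 13000 nM, the second highest of the three numbers: a 1.2-fold lower number from compound 1 to compound 3 (0.06 log units; within the scatter), while a 6.5-fold higher number from compound 2 to compound 3 (0.81 log units; beyond the scatter). Compound 4, `O=S(=O)(NCCCNCc1ccccc1)c1cc(C(F)(F)F)cc(C(F)(F)F)c1`, is the next step: hydrogen in place of chloro on an aromatic carbon, that is, 2-chlorophenyl to phenyl. For the measured compounds named here, no measured step removes a single substituent; the steps so far swap whole aryl groups, and the nearest comparison, a 1.2-fold lower number from compound 1 to compound 3 (0.06 log units; within the scatter), lies within the scatter. No step beyond the scatter is therefore expected in this assay, in either direction. Compound 4 is estimated at 13000 nM (range 5000 nM to 35000 nM), meaning an expected no change at the digits printed from compound 3 to compound 4 (within the scatter).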

Compound 4, concentration for 50% growth inhibition: 14000 nM
For compound 4 the middle estimate is 1.1-fold (0.03 log units) below the measured one; measured number inside the range.
By their numbers in this assay, from the lowest: compound 2; then compounds 3, 4 and 1 (each within the scatter of the next).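

In this assay, taking the chloro off this aromatic carbon makes no difference beyond the scatter, with a 1.1-fold higher number from compound 3 to compound 4 (0.03 log units; within the scatter), and the same holds for phenyl against 3,4-dimethoxyphenyl, with a 1.1-fold lower number from compound 1 to compound 4 (0.03 log units; within the scatter). Only compound 2 stands apart, with a 7.0-fold higher number from compound 2 to compound 4 (0.85 log units; beyond the scatter), so among these four compounds, a trifluoromethyl group on the ring goes with the stronger growth inhibition, while chloro, two methoxy groups and bare phenyl cannot be told apart. No measurement here explains this. On these data alone, whether a nitrile or a carboxylic acid on this ring would match trifluoromethyl remains open, as does the effect of a longer chain in the shared core.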